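Amide substituent at the carbonyl carbon of the shared core

The compounds below may be only part of what the source reports. "The series", "measured", "known", "first", "only" and "open" are said of these compounds alone.

Compound 2 `COc1ccc2c(c1)OC(c1cc(OC)c(OC)c(OC)c1)C(C(=O)N(C)OC)=C2` gives 11700 nM in a functional assay for inhibition of nuclear factor NF-kappa-B complex (Homo sapiens); on this read-out lower numbers stand for stronger inhibition and higher numbers for weaker inhibition. Compound 3 `CCCC(=O)C1=Cc2ccc(OC)cc2OC1c1cc(OC)c(OC)c(OC)c1` gives 11700 nM in this assay, and the step of no change at the digits printed from compound 2 to compound 3 (within the scatter) leaves the two level. For compound 1 `COc1ccc2c(c1)OC(c1cc(OC)c(OC)c(OC)c1)C(C(=O)N1CCCCC1)=C2` the value in this assay is a limit of the assay, > 50000 nM (the limit of > 50000 nM in this assay, at which 1 of the 3 values shown sits). From there the steps of an at least 4.2-fold lower number from compound 1 to compound 2 (0.63 log units; beyond the scatter) and an at least 4.2-fold lower number from compound 1 to compound 3 (0.63 log units; beyond the scatter) were both at least modest. Compound 4 `COc1ccc2c(c1)OC(c1cc(OC)c(OC)c(OC)c1)C(C(N)=O)=C2` differs from compound 2 by amino in place of methoxy(methyl)amino on a carbonyl carbon. All three measured steps sit on the same carbonyl carbon: methoxy(methyl)amino and propyl gave like numbers, while piperidin-1-yl gave only a limit. The expected step is a 1.3-fold higher number from compound 2 to compound 4 (0.11 log units; within the scatter), within the scatter or slightly weaker. For compound 4 the estimate is 15000 nM, between 5000 nM and 50000 nM.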

Compound 4, half-maximal inhibitory concentration: > 50000 nM
Compound 4: no number, only a limit; the forecaster's own chance of this, stated with the estimate: 25%; middle value at least 3.3-fold (0.52 log units) from the limit.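

Compound 4 gives only a limit of the assay in this assay, > 50000 nM. Amino on this carbonyl carbon reads clearly weaker than either group that stays off the limit: an at least 4.2-fold higher number from compound 2 to compound 4 (0.63 log units; beyond the scatter), and an at least 4.2-fold higher number from compound 3 to compound 4 (0.63 log units; beyond the scatter), so the limit is not confined to piperidin-1-yl. The step between compound 1 and compound 4 cannot be read, with both at the limit: the limit of > 50000 nM in this assay, at which 2 of the 4 values shown sit.

Open, going by these compounds, is whether a dimethylamino group or a longer chain on the same carbonyl carbon would give a lower number than compound 2 and compound 3.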